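This account rests on a few compounds, and the source may have more. Where it says the series, first, only, none or still open, it means among the compounds named here.

Going by the values given here, compound 3 `O=C1C=CC(OCC(F)(F)F)N1c1ccccc1` gives 23400 nM in a functional assay on A549 cells (Homo sapiens) for inhibition (on this read-out higher numbers stand for weaker inhibition and lower numbers for stronger inhibition), the highest of the three numbers measured so far. Compound 1 `O=C1C=CC(OCC(F)(F)F)N1c1ccc(C(F)(F)F)cc1` gives 8390 nM in this assay, and compound 2 `CCc1ccc(N2C(=O)C=CC2OCC(F)(F)F)cc1` gives 8090 nM; the step of a 1.0-fold lower number from compound 1 to compound 2 (0.02 log units; within the scatter) shows that these two cannot be told apart. Both carry a group on the aromatic ring where compound 3 has only hydrogen: replacing trifluoromethyl by hydrogen gives a 2.8-fold higher number from compound 1 to compound 3 (0.45 log units; beyond the scatter), and replacing ethyl by hydrogen gives a 2.9-fold higher number from compound 2 to compound 3 (0.46 log units; beyond the scatter). In both cases the number rose by a modest, comparable amount.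

Compound 4 `O=C1C=CC(OCC(F)(F)F)N1c1ccc([N+](=O)[O-])cc1` differs from compound 3 by nitro in place of hydrogen on an aromatic carbon. The two steps above are the ones that bear on it, since each of them concerns a group at this position of the shared core against hydrogen, and each lowered the number by a modest amount when the group was present. Nitro has not been measured on this core, so the size of its effect is open, but the same direction is expected, with a step of about a 2.6-fold lower number from compound 3 to compound 4 (0.41 log units; beyond the scatter) in this assay. Compound 4 is therefore estimated at 9000 nM in this assay, with a range from 4000 nM to 25000 nM.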

Compound 4, half-maximal inhibitory concentration: 3270 nM
Estimate against measurement, compound 4: 2.8-fold (0.44 log units) above; the whole stated range lies above it.
By their numbers in this assay, from the lowest: compound 4; then compounds 2 and 1 (each within the scatter of the next); then compound 3.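

In this assay, nitro on the aromatic carbon para to a large group gives the largest drop from hydrogen seen so far at this position: a 7.2-fold lower number from compound 3 to compound 4 (0.85 log units; beyond the scatter). Compounds 1 and 2 could not be told apart and might have suggested a common level for any group here, but nitro goes beyond both, with a 2.5-fold lower number from compound 2 to compound 4 (0.39 log units; beyond the scatter) and a 2.6-fold lower number from compound 1 to compound 4 (0.41 log units; beyond the scatter), so the identity of the group at this position matters and neither ethyl nor trifluoromethyl marks the lowest number reachable. Nothing available here accounts for the difference between nitro and the other two groups.

Going by these compounds alone, with only three groups compared against hydrogen, it remains open whether an amine, a carboxylic acid or a nitrile on the same aromatic carbon would fall near compound 4, near compounds 1 and 2, or outside that span. Going by these compounds, it is equally open whether the advantage of nitro would persist if a longer chain or an amine replaced the fluorinated ether group on the shared core.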